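This account rests on a few compounds, and the source may have more. Where it says the series, first, only, none or still open, it means among the compounds named here.

Measured in a functional assay on MCF7 cells (Homo sapiens) for cytotoxicity, read by MTT assay, with a stated time of 48 h; on this read-out higher numbers stand for weaker inhibition and lower numbers for stronger inhibition:
compound 1, `COc1cc(-c2nnc3n2NC(c2cccs2)C(C(=O)c2ccc(C)cc2)S3)cc(OC)c1OC`, gives 28400 nM.
compound 2, `COc1cc(-c2nnc3n2NC(c2ccco2)C(C(=O)C2CC2)S3)cc(OC)c1OC`, gives only the assay limit > 100000 nM, not a number.

Compound 2 thus stands at the limit of this assay, (the limit of > 100000 nM in this assay, at which 1 of the 2 values shown sits). Compound 3, `COc1cc(-c2nnc3n2NC(c2ccco2)C(C(=O)c2ccc([N+](=O)[O-])cc2)S3)cc(OC)c1OC`, carries 4-nitrophenyl in place of cyclopropyl on a carbonyl carbon, that is 4-nitrophenyl in place of cyclopropyl on a carbonyl carbon. Going by the values given here, no step between two measured compounds is at hand, so no size can be read off for this change. Because compound 1 gives 28400 nM in this assay, a return into the measurable range is expected, with an estimated step of an at least 3.3-fold lower number from compound 2 to compound 3 (0.52 log units; beyond the scatter). Compound 3 is estimated at 30000 nM, within 8000 nM to 100000 nM.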

Compound 3, half-maximal inhibitory concentration: > 100000 nM
Compound 3 gave a limit, no number; the forecaster's own chance of this, stated with the estimate: 30%; middle value at least 3.3-fold (0.52 log units) away from the limit.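

Compound 2 and compound 3 both give only a limit, not a number, so no step can be read between them: the limit of > 100000 nM in this assay, at which 2 of the 3 values shown sit.

Going by these compounds, whether 4-nitrophenyl in place of cyclopropyl on a carbonyl carbon changes the read-out at all remains open.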